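Pyridinyl for pyrimidinyl on the sulfonamide: compound 4

The compounds below may be only part of what the source reports. "The series", "measured", "known", "first", "only" and "open" are said of these compounds alone.

Compound 1 `O=C1/C(=C/c2coc3ccccc3c2=O)N=C(c2ccc(Cl)cc2)N1c1ccc(S(=O)(=O)Nc2ncccn2)cc1` serves as the reference. In a functional assay on A549 cells (Homo sapiens) for cytotoxicity, read by sulforhodamine B assay, with a stated time of 72 h (on this read-out higher numbers stand for weaker inhibition and lower numbers for stronger inhibition), compound 1 gives 59000 nM. Compound 2 `O=C1/C(=C/c2coc3ccccc3c2=O)N=C(c2ccc(Cl)cc2)N1c1ccc(S(=O)(=O)Nc2ccccn2)cc1` carries pyridin-2-yl in place of pyrimidin-2-yl on a sulfonamide nitrogen. In this assay compound 2 is reported only as a limit of the assay, > 100000 nM. The step is therefore an at least 1.6-fold higher number from compound 1 to compound 2 (0.22 log units; that floor lies within the scatter), and its size is bounded by the limit of > 100000 nM in this assay, at which 1 of the 3 values shown sits. Compound 3 `O=C1/C(=C/c2coc3ccccc3c2=O)N=C(c2ccccc2)N1c1ccc(S(=O)(=O)Nc2ncccn2)cc1` differs from compound 1 by hydrogen in place of chloro on an aromatic carbon. In this assay compound 3 gives 40500 nM, a step of a 1.5-fold lower number from compound 1 to compound 3 (0.16 log units; within the scatter), so the two cores read as interchangeable within the scatter.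

Compound 4 `O=C1/C(=C/c2coc3ccccc3c2=O)N=C(c2ccccc2)N1c1ccc(S(=O)(=O)Nc2ccccn2)cc1` has not been measured. It differs from compound 3 by pyridin-2-yl in place of pyrimidin-2-yl on a sulfonamide nitrogen, the same change already made from compound 1 to compound 2 at an identical place. For the measured compounds named here, the only guide is an at least 1.6-fold higher number from compound 1 to compound 2 (0.22 log units; that floor lies within the scatter), which is itself only a floor. Going by the values given here, the expected step is estimated as a 2.2-fold higher number from compound 3 to compound 4 (0.35 log units; beyond the scatter), resting on that single bounded step, with no second example to sharpen it. Compound 4 is accordingly expected to give about 90000 nM in this assay, with a plausible range from 40000 nM to 200000 nM, and a real chance that only a limit is returned.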

Compound 4, half-maximal inhibitory concentration: > 100000 nM
Compound 4: only a limit was reported (the forecaster's own chance of this, stated with the estimate: 45%); middle value at least 1.1-fold (0.04 log units) from the limit.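

Carried onto the core of compound 3, pyridin-2-yl in place of pyrimidin-2-yl on a sulfonamide nitrogen gives an at least 2.4-fold higher number from compound 3 to compound 4 (0.39 log units; beyond the scatter) in this assay, and this step lies beyond the scatter, while the floor of the first example does not. Set side by side, the two examples cannot be ranked: the same change on two cores in this assay, an at least 1.6-fold higher number (0.22 log units; that floor lies within the scatter) from compound 1 to compound 2 and an at least 2.4-fold higher number (0.39 log units; beyond the scatter) from compound 3 to compound 4; the limit leaves it open whether they differ Neither core goes against a higher number with pyridin-2-yl, but compound 2 and compound 4 are both reported only as limits, so the true size of the change on either core remains unknown and the step between these two compounds cannot be read: the limit of > 100000 nM in this assay, at which 2 of the 4 values shown sit.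

Still open, on these data alone, is how thiazol-2-yl or a plain methyl group on a sulfonamide nitrogen would read in this assay, set against pyrimidin-2-yl on the same core. Also open, as far as these compounds go, is whether methoxy in place of chloro on an aromatic carbon would stay within the scatter of compound 1, as hydrogen does.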